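From a Nitrophenyl Amide to an Acetylpiperidine Amide

A few compounds are considered here, and "the series" means these few. Any claim that something is new, unique, unknown or untested is made for them only; others in the source may bear on it.

compound 1 `O=S(=O)(Nc1ccc(-c2nc3cc(NS(=O)(=O)c4cccc(C(F)(F)F)c4)ccc3o2)cc1)c1cccc(C(F)(F)F)c1` - 15000 nM
compound 2 `COc1ccc(S(=O)(=O)Nc2ccc3oc(-c4ccc(NC(=O)c5cccc(C)c5[N+](=O)[O-])cc4)nc3c2)cc1` - 1500 nM
compound 3 `O=C(Nc1ccc(Sc2nc3ccccc3s2)c(Cl)c1)c1cccc(Br)c1O` - 22000 nM

In a functional assay on DLD-1 cells (Homo sapiens) for cytotoxicity, read by resazurin assay, with a stated time of 48 h (a lower number here means that less compound is needed, a higher number that more compound is needed for the effect), compound 2 stands lowest of the three at 1500 nM and the other two lie beyond the scatter from it. The next structure, compound 4 `COc1ccc(S(=O)(=O)Nc2ccc3oc(-c4ccc(NC(=O)C5CCN(C(C)=O)CC5)cc4)nc3c2)cc1`, carries 1-acetylpiperidin-4-yl in place of 3-methyl-2-nitrophenyl on a carbonyl carbon. For the measured compounds named here, no measured step tests such a change. Since compound 2 at 1500 nM holds the lowest number, a move toward higher numbers seems likelier than a further fall. In this assay the expected size of the change is a 4.0-fold higher number from compound 2 to compound 4 (0.60 log units; beyond the scatter) and it would lie beyond the scatter, towards a higher number. For compound 4 the estimated value is 6000 nM (range 1800 nM to 20000 nM).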

Compound 4, half-maximal effective concentration: 15000 nM
Compound 4: the middle estimate sits 2.5-fold (0.40 log units) below what was measured, within the range that was stated.
By their numbers in this assay, from the lowest: compound 2; then compounds 1, 4 and 3 (each within the scatter of the next).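

In this assay, for the compounds shown here, 1-acetylpiperidin-4-yl in place of 3-methyl-2-nitrophenyl on a carbonyl carbon gives a 10-fold higher number from compound 2 to compound 4 (1.00 log units; beyond the scatter) and so supplies the first measured step at this position. It shows that the group on this carbonyl carbon can shift the number beyond the scatter while the rest of compound 2 stays the same. Nothing given here speaks to what lies behind this step. Going by these compounds, what a plain phenyl or an unacetylated piperidine amine would give at this position remains open.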